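Replacing an aminophenyl amide with a methylpyridinyl amide

This account rests on a few compounds, and the source may have more. Where it says the series, first, only, none or still open, it means among the compounds named here.

Compound 1 `Nc1ccc(NC(=O)c2c(O)c3cccnc3n(-c3ccccc3)c2=O)cc1` stands lowest of the three measured compounds in a functional assay on the whole organism for inhibition, with Rattus norvegicus as the target, read by paw edema, at a dose of 100 mg/kg by the oral route (on this read-out higher numbers stand for more inhibition at the one dose given (going by the name of the read-out) and lower numbers for less inhibition), giving -5.5%. Compound 2 `Cc1ccccc1NC(=O)c1c(O)c2cccnc2n(-c2ccccc2)c1=O` gives 11.7% and compound 3 `O=C(Nc1cnccn1)c1c(O)c2cccnc2n(-c2ccccc2)c1=O` gives 29.6%. The step to compound 4 `Cc1cnccc1NC(=O)c1c(O)c2cccnc2n(-c2ccccc2)c1=O` changes the amide substituent: 3-methylpyridin-4-yl in place of 4-aminophenyl on an amide-type nitrogen. For the measured compounds named here, two measured steps bear on it. Putting a methyl-bearing phenyl ring in place of the aminophenyl gave a number 17.2 percentage points higher from compound 1 to compound 2 (beyond the scatter), and putting a nitrogen-containing six-membered ring in that place gave a number 35.1 percentage points higher from compound 1 to compound 3 (beyond the scatter). Compound 4 carries both a methyl group and a ring nitrogen, so a rise beyond the scatter is expected, of about a number 29.5 percentage points higher from compound 1 to compound 4 (beyond the scatter). Compound 4 is therefore estimated to give 24%, within a range from 6% to 42%.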

Compound 4, a percentage reported as inhibition, in the whole organism at one dose (the size of the read-out at that dose, not a potency): 26.9%
Beside the measured number, compound 4's estimate is 2.9 percentage points below it; measured number inside the range.
By their numbers in this assay, from the lowest: compound 1; then compound 2; then compounds 4 and 3 (each within the scatter of the next).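

On the amide-type nitrogen, 3-methylpyridin-4-yl gives a large gain over 4-aminophenyl (a number 32.4 percentage points higher from compound 1 to compound 4 (beyond the scatter)) in this assay, which shows that a methyl group and a ring nitrogen can be carried on one ring. The same group also stands clear of 2-methylphenyl (a number 15.2 percentage points higher from compound 2 to compound 4 (beyond the scatter)), so among these methyl-bearing rings the one with a ring nitrogen gives the higher number. It cannot be told apart from pyrazin-2-yl (a number 2.7 percentage points lower from compound 3 to compound 4 (within the scatter)).

No evidence accounts for these differences. As far as these compounds go, whether an unsubstituted pyridin-4-yl or a carboxylic acid on the ring would go beyond this level remains open.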